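The source may report more compounds than this note shows. Statements on the series, on what has been measured and on what is new or still open speak of the compounds shown alone.

Compound 1 `Cc1ccc(CN2C(=O)S/C(=C\c3ccc([N+](=O)[O-])cc3)C2=O)cc1` and compound 2 `Cc1ccc(CN2C(=O)S/C(=C\c3ccccc3Cl)C2=O)cc1` share one core and differ only in the ring that hangs from it. In a functional assay on the whole organism (plasma) with Mus musculus as the target, with a stated time of 15 days, at a dose of 30 mg/kg by the oral route (a higher number here means a stronger effect of the compound at the dose given, a lower number a weaker effect), compound 1 gives 7.1%, while compound 2 gives 26%. Within the data shown here, compound 2 thus holds the higher of the two numbers measured so far, and its only neighbour, compound 1, sits lower by a gap that exceeds the usual scatter of such measurements.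

Compound 3 `Cc1ccc(CN2C(=O)S/C(=C\OCc3ccccc3)C2=O)cc1` has not yet been measured. Compared with compound 2 it shows the change (benzyloxy in place of 2-chlorophenyl on a double-bonded chain carbon bound to a double-bonded ring carbon), so the benzyloxy group takes the spot that the 2-chlorophenyl held on a double-bonded chain carbon bound to a double-bonded ring carbon. Among the measured compounds shown here, no measured pair of compounds shows an exchange of this kind, so there is no measured step to lean on; the data only show that changing this ring moved the read-out from compound 1 to compound 2.

The step expected in this assay is a number 11 percentage points lower from compound 2 to compound 3 (beyond the scatter), a moderate fall that may or may not exceed the scatter. Compound 3 is expected to give about 15%, with a range from 0% to 35%.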

Compound 3, a percentage reported as activity, at one dose (the size of the read-out at that dose, not a potency): 42.1%
Estimate against measurement, compound 3: 27.1 percentage points below; the whole stated range lies below it.
By their numbers in this assay, from the lowest: compound 1; then compound 2; then compound 3.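

In this assay the exchange of 2-chlorophenyl for benzyloxy on a double-bonded chain carbon bound to a double-bonded ring carbon gives a number 16.1 percentage points higher from compound 2 to compound 3 (beyond the scatter) and so shows, for this pair, that the spot can take more than a ring attached straight to the chain. Both groups carry one six-membered aromatic ring of carbon only, but in benzyloxy that ring is linked through oxygen and carbon, and the change also removes the chlorine and adds one hydrogen-bond acceptor. Nothing measured for these compounds explains why the read-out moved in this direction.

The oxygen, the added carbon and the loss of chlorine all change in this one exchange, so the compounds shown cannot say which of them matters, or whether they only matter together. From the compounds shown here alone, it also remains open how this spot would respond to an amine, a carboxylic acid or a longer chain ending in the same aromatic ring.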